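Swapping a side chain for methyl on compound 3

A few compounds are considered here, and "the series" means these few. Any claim that something is new, unique, unknown or untested is made for them only; others in the source may bear on it.

Measured in an ADME assay on HepG2 2.2.15 cells (Homo sapiens) for cytotoxicity, read by MTT assay, with a stated time of 8 days (a lower number here means that less compound is tolerated, a higher number that more compound is tolerated), each value a limit of the assay and not a number:
- Compound 1 `COCCNc1nc(F)c(-c2nn(Cc3ccc(C#N)cc3)c(=O)c3ccccc23)cc1Cl`: > 100000 nM
- Compound 2 `COC(=O)c1cc(-c2ccc(F)nc2F)nn(Cc2ccc(Cl)cc2)c1=O`: > 100000 nM
- Compound 3 `COCCNc1ccc(-c2nn(Cc3ccc(C#N)cc3)c(=O)c3ccccc23)c(F)n1`: > 100000 nM

Compound 3 gives > 100000 nM, which is a limit. The whole set looks alike, with the limit of > 100000 nM in this assay, at which 3 of the 3 values shown sit. So all that is known of compound 3 is that it shares this limit with the other two compounds.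

Compound 4 `Cc1ccc(-c2nn(Cc3ccc(C#N)cc3)c(=O)c3ccccc23)c(F)n1` keeps the shared core of compound 3 and changes one group: methyl in place of (2-methoxyethyl)amino on an aromatic carbon. This puts methyl in place of (2-methoxyethyl)amino on an aromatic carbon, next to the ring nitrogen and para to a large group.

The only measured step between two of these compounds is a step that the two limits leave unreadable from compound 1 to compound 3. It concerns hydrogen in place of chloro, so it is a different change, and its size cannot be read anyway. For the measured compounds named here, no measured step touches the (2-methoxyethyl)amino group, which leaves no size to carry over and no direction to favour.

The expectation therefore leans on compound 3 and its limit of > 100000 nM. The expected result is a number no higher from compound 3 to compound 4 (the limit leaves the size open), with no shift beyond the usual scatter. The estimated value for compound 4 is 100000 nM, within an expected range of 30000 nM to 200000 nM.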

Compound 4, half-maximal cytotoxic concentration: > 100000 nM
Compound 4 was reported as a limit; the forecaster's own chance of this, stated with the estimate: 70%; the middle value sits exactly at the limit.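

Compound 3 and compound 4 each give only a limit of the assay, not a number, so no step can be read between them, and the whole set stays at that limit: the limit of > 100000 nM in this assay, at which 4 of the 4 values shown sit. The compounds shown leave open what methyl in place of (2-methoxyethyl)amino does to the true value in this assay.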